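Notes on lengthening the chain of compound 2

The source may hold more compounds than are shown below. What is called first, only, known or untested is meant among the compounds shown, and "the series" means these compounds.

Values in a functional assay on A2780 cells (Homo sapiens) for antiproliferative activity, read by MTT assay, with a stated time of 72 h (a higher number here means a weaker inhibitor, a lower number a stronger inhibitor), so far
- compound 1 `N=C(NC(=N)NC1CCCC1)Nc1ccc(C(F)(F)F)cc1` gives 2500 nM
- compound 2 `CC(C)CNC(=N)NC(=N)Nc1ccc(F)c(F)c1` gives 6700 nM

Compound 2 holds the higher number of the two, and its gap to compound 1 lies beyond the scatter. Among the compounds with values here, no measured step isolates a single change. Compound 3 `CCCCCCCNC(=N)NC(=N)Nc1ccc(F)c(F)c1` differs by hexyl in place of isopropyl on a saturated chain carbon bound to an amine nitrogen and so has hexyl in place of isopropyl on a saturated chain carbon bound to an amine nitrogen. Within the data shown here, with no measured precedent, a moderate fall in the number, beyond the scatter, is expected in this assay for this change. The expected move is a 3.0-fold lower number from compound 2 to compound 3 (0.48 log units; beyond the scatter) and its size remains uncertain. Compound 3 is estimated at 2200 nM with 700 nM to 6000 nM as expected bounds.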

Compound 3, half-maximal inhibitory concentration: 1500 nM
Estimate against measurement, compound 3: 1.5-fold (0.17 log units) above, and the stated range covers the measured number.
By their numbers in this assay, from the lowest: compounds 3 and 1 (each within the scatter of the next); then compound 2.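

In this assay, within the data shown here, hexyl in place of isopropyl on a saturated chain carbon bound to an amine nitrogen gives a 4.5-fold lower number from compound 2 to compound 3 (0.65 log units; beyond the scatter), the first measured step that isolates a single change. This position therefore responds to the group it carries, at least for this pair. Nothing available accounts for the step.

Still open, from the compounds shown here alone, is whether a chain longer than hexyl moves the number further, or whether an amine or a carboxylic acid on the chain preserves the step. Going by these compounds, it is also open whether the same change would carry over to the core of compound 1.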